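Dichlorophenyl isomers in the series: compound 2 to compound 4

The compounds below may be only part of what the source reports. "The series", "measured", "known", "first", "only" and "open" are said of these compounds alone.

Measured in a functional assay on HL-60 cells (Homo sapiens) for antiproliferative activity, read by MTT assay, with a stated time of 72 h (on this read-out higher numbers stand for weaker inhibition and lower numbers for stronger inhibition), as follows:
- compound 1 `COc1ccc(OCCCON2C(N)=NC(N)=NC23CCOCC3)cc1` gives 1670 nM
- compound 2 `NC1=NC2(CCOCC2)N(OCCCOc2cccc(Cl)c2Cl)C(N)=N1` gives 440 nM
- compound 3 `NC1=NC2(CCSCC2)N(OCCCOc2cccc(Cl)c2Cl)C(N)=N1` gives 30 nM

Compound 2 stands second highest of the three numbers, with compound 1 above it and compound 3 below it, both gaps beyond the scatter. The next compound to be read is compound 4 `NC1=NC2(CCOCC2)N(OCCCOc2ccc(Cl)c(Cl)c2)C(N)=N1` with this counted difference: 3,4-dichlorophenyl in place of 2,3-dichlorophenyl on an oxygen on a saturated carbon. In words, it has 3,4-dichlorophenyl in place of 2,3-dichlorophenyl on an oxygen on a saturated carbon, so the two share the same atoms, joined differently.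

For the measured compounds named here, one measured step bears on this place: a 3.8-fold lower number from compound 1 to compound 2 (0.58 log units; beyond the scatter). That step exchanged 4-methoxyphenyl for 2,3-dichlorophenyl, and it is modest. Compound 2 and compound 3 carry the same 2,3-dichlorophenyl and differ only in the shared core, so the value of compound 3 at 30 nM says nothing about this change. Going by the values given here, no measured pair compares two dichlorophenyl groups.

Set against a 3.8-fold lower number from compound 1 to compound 2 (0.58 log units; beyond the scatter) a step of no greater size is expected in this assay with no direction favoured, so none beyond the scatter is the working expectation. The estimated change is a 1.1-fold lower number from compound 2 to compound 4 (0.04 log units; within the scatter) on this reading. For compound 4 the estimated value is 400 nM with an expected range from 130 nM to 1200 nM for now.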

Compound 4, half-maximal inhibitory concentration: 1240 nM
For compound 4 the middle estimate is 3.1-fold (0.49 log units) below the measured one, and the stated range ends below it.
By their numbers in this assay, from the lowest: compound 3; then compound 2; then compounds 4 and 1 (each within the scatter of the next).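

In this assay this place on the oxygen on a saturated carbon now separates two groups with the same atoms, joined differently: the 3,4-dichlorophenyl group gives a higher number than the 2,3-dichlorophenyl group (a 2.8-fold higher number from compound 2 to compound 4 (0.45 log units; beyond the scatter)). The earlier step from the 4-methoxyphenyl group to the 2,3-dichlorophenyl group therefore cannot be read as holding for dichlorophenyl groups in general, and compound 4 goes against any such reading, since it stays within the scatter of the 4-methoxyphenyl compound (a 1.3-fold lower number from compound 1 to compound 4 (0.13 log units; within the scatter)). Nothing available explains the difference between the two isomers.

For the compounds shown here, it remains open whether the 3,4-dichlorophenyl group would keep the same relation to the 2,3-dichlorophenyl group on the core of compound 3 (30 nM), the only compound here that carries that core. Also open, as far as these compounds go, is how the series responds in this place to other groups, such as 2,4-dichlorophenyl, 3,5-dichlorophenyl, or a phenyl ring bearing an amine or a carboxylic acid.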